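The compounds below may be only part of what the source reports. "The series", "measured", "known", "first", "only" and "open" are said of these compounds alone.

Measured so far, each value being a limit of the assay rather than a number:

Compound 1 `Fc1ccc(Nc2nc(-c3cccc(F)c3)nc3ccc(F)cc23)cc1` gives in a functional assay on U2OS cells (Homo sapiens) for cytotoxicity, read by MTT assay, with a stated time of 48 h (on this read-out lower numbers stand for stronger inhibition and higher numbers for weaker inhibition), the limit > 50000 nM.
Compound 2 `Fc1cccc(-c2nc(Nc3ccccc3F)c3cc(F)ccc3n2)c1` gives in this assay the limit > 50000 nM.
Compound 3 `Oc1ccc(Nc2nc(-c3cccc(F)c3)nc3ccc(F)cc23)cc1` gives in this assay the limit > 50000 nM.

Compound 1 thus stands only at a limit in this assay, and so do the two compounds around it; this is the limit of > 50000 nM in this assay, at which 3 of the 3 values shown sit. The step that the two limits leave unreadable from compound 1 to compound 2 and the step that the two limits leave unreadable from compound 2 to compound 3 both change the group on the nitrogen on the aromatic ring, and the step that the two limits leave unreadable from compound 1 to compound 3 changes a substituent on that group, but all three run between limits and none gives a readable size.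

Compound 4 `Nc1ccccc1Nc1nc(-c2cccc(F)c2)nc2ccc(F)cc12` differs from compound 1 by 2-aminophenyl in place of 4-fluorophenyl on a nitrogen on an aromatic ring. The change again touches the group on that nitrogen, and all that the measured steps show is that such changes have not brought any compound to a readable number. No step beyond the scatter is expected in this assay, in either direction, and compound 4 is expected to sit at the limit as well, estimated at 60000 nM within 20000 nM to 200000 nM. The expected step is a step that the limit leaves unreadable from compound 1 to compound 4.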

Compound 4, half-maximal inhibitory concentration: 37900 nM
For compound 4 the middle estimate is 1.6-fold (0.20 log units) above the measured one, and the stated range covers the measured number.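

In this assay compound 4 is the only compound shown that gives a number rather than a limit, so a group on this nitrogen can bring a value into readable range: the limit of > 50000 nM in this assay, at which 3 of the 4 values shown sit. The size of that change stays small or unknown, as the readable steps are an at least 1.3-fold lower number from compound 1 to compound 4 (0.12 log units; that floor lies within the scatter), an at least 1.3-fold lower number from compound 3 to compound 4 (0.12 log units; that floor lies within the scatter) and an at least 1.3-fold lower number from compound 2 to compound 4 (0.12 log units; that floor lies within the scatter). Each of these is only a floor, so 2-aminophenyl is not shown to do more than the other groups, and the steps among the three limit compounds cannot be read.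

The compounds shown leave open how far each of those three lies from compound 4. They also leave open what a carboxylic acid or a longer chain would give in place of the amino group of 2-aminophenyl.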